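Swapping chloro for bromo in a cytotoxic series

The compounds below may be only part of what the source reports. "The series", "measured", "known", "first", "only" and "open" are said of these compounds alone.

Compound 1 `COc1ccccc1Oc1c(N)nc(-c2ccc(C)cc2)nc1Cl`: > 80000 nM, a limit of the assay
Compound 2 `COc1ccccc1Oc1c(N)nc(-c2ccc(Cl)cc2)nc1Cl`: 1030 nM

Among the measured compounds shown here, in a functional assay on A-375 cells (Homo sapiens) for cytotoxicity, read by CCK-8 assay, with a stated time of 24 h (a higher number here means a weaker inhibitor, a lower number a stronger inhibitor), compound 2 gives 1030 nM, the only true number so far. Compound 1 is reported only as a limit, > 80000 nM.

For the measured compounds named here, the one measured step is an at least 77-fold lower number from compound 1 to compound 2 (1.89 log units; beyond the scatter), and it comes with chloro in place of methyl on an aromatic carbon. A change at this place can therefore matter a great deal, at least for these two compounds.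

Compound 3 `COc1ccccc1Oc1c(N)nc(-c2ccc(Br)cc2)nc1Cl` has bromo in place of chloro on an aromatic carbon. Going by the values given here, no measured step tests bromo, so the step from methyl to chloro is only a loose guide. It shows that this place is sensitive, but not how one halogen compares with another. A small step, with no clear direction and none beyond the usual scatter, is the most reasonable expectation, starting from compound 2 at 1030 nM.

The expected change is a 1.1-fold lower number from compound 2 to compound 3 (0.06 log units; within the scatter).

For compound 3, the estimated value is 900 nM, with an expected range from 350 nM to 2500 nM.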

Compound 3, half-maximal inhibitory concentration: 63 nM
For compound 3 the middle estimate is 14-fold (1.15 log units) above the measured one, and the stated range ends above it.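

In this assay, the swap that looked minor turns out to be large: replacing chloro with bromo on this ring gives a 16-fold lower number from compound 2 to compound 3 (1.21 log units; beyond the scatter) and so separates two halogens as clearly as the earlier step separated methyl from chloro. This position therefore responds not only to whether a halogen is present but also to which halogen it carries, and in these compounds bromo gives the lowest number. Across the full series of three groups, the change from methyl to bromo amounts to an at least 1200-fold lower number from compound 1 to compound 3 (3.10 log units; beyond the scatter) and shows how much a single atom or small group at this one place can alter the result in this cell assay, but compound 1 stands only as a limit: the limit of > 80000 nM in this assay, at which 1 of the 3 values shown sits.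

Iodo and fluoro remain open, as do an amine and a carboxylic acid at the same place, so it is unknown whether the numbers keep falling beyond bromo or whether only certain groups give low values. Three compounds give an order of groups but no explanation for why bromo and chloro differ so much.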